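Notes on a Dimethylanilide Analogue in the Series

The source may report more compounds than this note shows. Statements on the series, on what has been measured and on what is new or still open speak of the compounds shown alone.

Measured compounds in a functional assay on CCRF-CEM cells (Homo sapiens) for cytotoxicity; a higher number here means a weaker inhibitor, a lower number a stronger inhibitor:
compound 1, `Cc1ccc(NC(=O)/C=C/C(=O)N2C/C(=C\c3ccccc3)C(=O)/C(=C/c3ccccc3)C2)cc1`, gives 1100 nM
compound 2, `COc1ccc(NC(=O)/C=C/C(=O)N2C/C(=C\c3ccc([N+](=O)[O-])cc3)C(=O)/C(=C/c3ccc([N+](=O)[O-])cc3)C2)cc1`, gives 760 nM
compound 3, `CC(=O)c1ccc(NC(=O)/C=C/C(=O)N2C/C(=C\c3ccc([N+](=O)[O-])cc3)C(=O)/C(=C/c3ccc([N+](=O)[O-])cc3)C2)cc1`, gives 360 nM

Compound 1 shows the highest number of the three, though compound 2 lies within the scatter of it; only compound 3 stands beyond the scatter, on the lower side. A single step between compounds that differ in one place is available, a 2.1-fold lower number from compound 2 to compound 3 (0.32 log units; beyond the scatter), and it concerns an exchange of one group for another on the anilide ring rather than the addition of a group.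

Compound 4, `Cc1ccc(NC(=O)/C=C/C(=O)N2C/C(=C\c3ccccc3)C(=O)/C(=C/c3ccccc3)C2)cc1C`, has not yet been measured. It differs from compound 1 by methyl in place of hydrogen on an aromatic carbon. Going by the values given here, no measured step bears directly on methyl in place of hydrogen on that ring, so the measured step from compound 2 to compound 3 offers no guide for direction. No step beyond the scatter is therefore expected in this assay in either direction.

Compound 4 is expected to give about 1000 nM in this assay, with a range from 450 nM to 2300 nM. The expected step is a 1.1-fold lower number from compound 1 to compound 4 (0.04 log units; within the scatter).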

Compound 4, half-maximal inhibitory concentration: 7100 nM
For compound 4 the middle estimate is 7.1-fold (0.85 log units) below the measured one; measured number outside the range, above it.
By their numbers in this assay, from the lowest: compound 3; then compounds 2 and 1 (each within the scatter of the next); then compound 4.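

In this assay, the change from 4-methylphenyl to 3,4-dimethylphenyl gives a 6.5-fold higher number from compound 1 to compound 4 (0.81 log units; beyond the scatter), so this position, ortho to a methyl group and meta to a large group, responds clearly to a single added methyl. The only earlier step was an exchange of methoxy for acetyl, which went the other way, so this is the first step shown in which adding a group to this ring raises the number. Nothing available here accounts for the rise.

Going by these compounds, it remains open whether the rise is particular to methyl or would also follow from a fluorine, a hydroxyl or an amine at this position. On these data alone, it also remains open whether the same added methyl would raise the number on the nitro-bearing scaffold of compound 2 and compound 3.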